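Benzylamino in place of ethoxy: cytotoxicity outlook

The source may report more compounds than this note shows. Statements on the series, on what has been measured and on what is new or still open speak of the compounds shown alone.

In an ADME assay on BCBL1 cells (Homo sapiens) for cytotoxicity, with a stated time of 7 days (on this read-out lower numbers stand for higher toxicity in this test and higher numbers for lower toxicity in this test), compound 1 `CCOc1nc(N)nc2c1ncn2/C=C1/CC1(CO)CO` gives only a limit of the assay, > 20000 nM. Compound 2 `COCCOc1nc(N)nc2c1ncn2/C=C1/CC1(CO)CO` likewise returns only a limit, > 20000 nM. The size of a step that the two limits leave unreadable from compound 1 to compound 2 is unreadable, since both values sit at the same boundary (the limit of > 20000 nM in this assay, at which 2 of the 2 values shown sit). Compound 3 `Nc1nc(NCc2ccccc2)c2ncn(/C=C3/CC3(CO)CO)c2n1` differs from compound 1 as follows: benzylamino in place of ethoxy on an aromatic carbon. No measured step matches this change; the single measured step alters the chain on the oxygen attached to the aromatic ring and is itself unreadable, so the shown data carry nothing on swapping an ethoxy group for a benzylamino group on the aromatic carbon. Among the measured compounds shown here, with both measured compounds returning only a limit in this assay, no step of a size beyond the scatter is expected in either direction for a step that the limit leaves unreadable from compound 1 to compound 3. Compound 3 is therefore estimated to give 30000 nM, within 8000 nM to 100000 nM.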

Compound 3, half-maximal cytotoxic concentration: 19900 nM
For compound 3 the middle estimate is 1.5-fold (0.18 log units) above the measured one, within the range that was stated.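

In this assay compound 3 gives 19900 nM, the only number in the series shown that is not a limit. Benzylamino on this aromatic carbon, next to the ring nitrogen, therefore brings the read-out to a measurable number, whereas the ethoxy and 2-methoxyethoxy compounds give only limits. The steps are a number no higher from compound 1 to compound 3 (the limit leaves the size open) and a number no higher from compound 2 to compound 3 (the limit leaves the size open) and their size cannot be read because of the boundary shared by the two ether compounds: the limit of > 20000 nM in this assay, at which 2 of the 3 values shown sit.

Benzylamino changes both the linking atom and the presence of a carbon-only aromatic ring, and the compounds shown do not separate the two. Methylamino or benzyloxy on the same aromatic carbon would bear on that question, and how far the value could fall with other amines remains open.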